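This account rests on a few compounds, and the source may have more. Where it says the series, first, only, none or still open, it means among the compounds named here.

Measured so far in a functional assay on MCF7 cells (Homo sapiens) for inhibition, read by sulforhodamine B assay, with a stated time of 48 h, tested at 50 uM; a lower number here means less inhibition of growth, a higher number more inhibition of growth at the concentration tested:
- compound 1 `COc1ccc([C@@H]2CC(=O)c3cc(CC=C(C)C)c(OC)cc3O2)cc1`: 65%
- compound 2 `COc1ccc([C@@H]2C/C(=N/OCc3cn(-c4ccc(C(=O)c5ccccc5)cc4)nn3)c3cc(CC=C(C)C)c(OC)cc3O2)cc1`: 41%
- compound 3 `COc1ccc([C@@H]2C/C(=N/OCc3cn(-c4cc(OC)c(OC)c(OC)c4)nn3)c3cc(CC=C(C)C)c(OC)cc3O2)cc1`: 45%

Among these three, compound 1 stands highest, and both of the others lie below it by more than the usual scatter of this assay. Compound 2 and compound 3 sit within the scatter of each other, so the data do not separate them.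

The next compound to be tested is compound 4 `C#CCOc1ccc([C@@H]2CC(=O)c3cc(CC=C(C)C)c(OC)cc3O2)cc1`. It keeps the core of compound 1 and changes in one place: ethynyl in place of hydrogen on a saturated chain carbon bound to an oxygen on an aromatic ring. In words, ethynyl stands in place of hydrogen on a saturated chain carbon bound to an oxygen on an aromatic ring, so a methoxy becomes a propargyloxy.

Going by the values given here, no two measured compounds differ in only one place, so the data offer no direct guide to this change. With so small an edit, a step beyond the scatter is not expected, though a slight downward lean seems likely, since compound 1 at 65% is the highest value seen so far. The estimated change, a number 5 percentage points lower from compound 1 to compound 4 (within the scatter), is therefore modest. For compound 4 the expected value is 60%, with an estimated range of 43% to 76%.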

Compound 4, percent growth inhibition at one concentration: 68%
Compound 4: the middle estimate sits 8 percentage points below what was measured, and the stated range covers the measured number.
By their numbers in this assay, from the lowest: compounds 2 and 3 (each within the scatter of the next); then compounds 1 and 4 (each within the scatter of the next).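

In this assay, replacing the methoxy with a propargyloxy gives a number 3 percentage points higher from compound 1 to compound 4 (within the scatter), so the added ethynyl on this saturated chain carbon bound to an oxygen on an aromatic ring leaves no difference that this assay can resolve. Going by these compounds alone, this is the first pair that differs in only one place, and it shows that this position can carry a propargyl in place of a methyl while growth inhibition remains within the usual scatter at the single concentration tested. Nothing measured here explains that outcome, and one pair says nothing about other positions on the shared core.

Still open, from the compounds shown here alone, is whether this tolerance extends to quite different groups at the same place, such as a longer saturated chain, an amine or a carboxylic acid in place of the ethynyl. A reading at one concentration also leaves open whether compound 1 and compound 4 would remain indistinguishable across a range of concentrations, where a difference hidden at this single test point could appear.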